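The compounds below may be only part of what the source reports. "The series", "measured", "known", "first", "only" and "open" are said of these compounds alone.

compound 1 `CC[C@@H](C)[C@H](NC(=O)c1ccc(Oc2nc3ccccc3nc2C)cc1)C(=O)OC` at 36100 nM
compound 2 `Cc1nc2ccccc2nc1Oc1ccc(C(=O)N[C@@H](CC(C)C)C(=O)O)cc1` at 14700 nM
compound 3 `CC[C@@H](C)[C@H](NC(=O)c1ccc(Oc2nc3ccccc3nc2C)cc1)C(=O)O` at 35700 nM

In a functional assay on MCF7 cells (Homo sapiens) for antiproliferative activity, read by MTT assay, with a stated time of 48 h (on this read-out lower numbers stand for stronger inhibition and higher numbers for weaker inhibition), compound 1 sits at the top of these numbers, level with compound 3 (a 1.0-fold lower number from compound 1 to compound 3 (0.00 log units; within the scatter)), while compound 2 lies lower (a 2.5-fold lower number from compound 1 to compound 2 (0.39 log units; beyond the scatter)). Compound 4 `CC[C@@H](C)[C@H](NC(=O)c1ccc(Oc2nc3ccccc3nc2NC(C)(C)C)cc1)C(=O)OC` differs from compound 1 on the core, with (tert-butyl)amino in place of methyl on an aromatic carbon. The measured steps alter only the ester methyl or the side chain on the amide nitrogen, and none exceeds modest size (a 2.4-fold higher number from compound 2 to compound 3 (0.39 log units; beyond the scatter)). None touches this aromatic carbon, so the data give no direction. No step beyond the scatter is therefore expected in this assay, though with wide uncertainty. The expected step is small (a 1.4-fold lower number from compound 1 to compound 4 (0.16 log units; within the scatter)) for now. For compound 4 the estimate is 25000 nM (expected range 7000 nM to 70000 nM).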

Compound 4, half-maximal inhibitory concentration: 33400 nM
Compound 4: middle estimate off by 1.3-fold (0.13 log units), on the low side; the range from low to high includes it.
By their numbers in this assay, from the lowest: compound 2; then compounds 4, 3 and 1 (each within the scatter of the next).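

In this assay, (tert-butyl)amino in place of methyl on the aromatic carbon next to the ring nitrogen leaves the number within the scatter (a 1.1-fold lower number from compound 1 to compound 4 (0.03 log units; within the scatter)). This carbon of the shared core therefore tolerates the larger group and its added hydrogen-bond donor in this assay, something the earlier changes at the ester methyl and the amide side chain could not show. No supporting measurement bears on this result. Still open, going by these compounds, is whether a primary amine, a methoxy group or a longer chain on this carbon would give a step beyond the scatter. Also open, on these data alone, is whether (tert-butyl)amino would behave alike on the free carboxylic acid of compound 3.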